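Swapping the Triazole for a Methylimidazole

The source may hold more compounds than are shown below. What is called first, only, known or untested is meant among the compounds shown, and "the series" means these compounds.

For the measured compounds named here, compound 2 `CC(C)C(c1nnc[nH]1)c1ccc(-c2ccc3cccc(F)c3c2)[nH]c1=O` has the shorter half-life of the two compounds measured so far: in an ADME assay on microsomes from liver (Mus musculus) for metabolic stability (on this read-out lower numbers stand for a shorter-lived compound and higher numbers for a longer-lived compound), compound 2 gives 0.213 h, while compound 1 `CCC(CC)(c1nnc[nH]1)c1ccc(-c2ccc3cccc(F)c3c2)[nH]c1=O` gives 0.447 h, a gap beyond the usual scatter. Compound 3 `Cc1c[nH]c(C(c2ccc(-c3ccc4cccc(F)c4c3)[nH]c2=O)C(C)C)n1` differs from compound 2 in one place: 4-methyl-1H-imidazol-2-yl in place of 4H-1,2,4-triazol-3-yl on a saturated chain carbon bound to an aromatic carbon and a saturated chain carbon. Going by the values given here, no measured pair shows this change, so its effect on half-life is unknown. The step of a 1.2-fold lower number from compound 2 to compound 3 (0.07 log units; within the scatter) is expected to be small, within the scatter, and if anything toward a shorter-lived compound. Compound 3 is estimated at 0.18 h, with a range from 0.08 h to 0.45 h.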

Compound 3, half-life: < 0.0667 h
Compound 3 ended at the assay's limit; the forecaster's own chance of this, stated with the estimate: 5%; middle value at least 2.6-fold (0.43 log units) from the limit.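

At this position, on a saturated chain carbon bound to an aromatic carbon and a saturated chain carbon, the choice of ring clearly matters in this assay: 4-methyl-1H-imidazol-2-yl in place of 4H-1,2,4-triazol-3-yl gives an at least 3.1-fold lower number from compound 2 to compound 3 (0.50 log units; beyond the scatter). The value of compound 3 is a limit of the assay and not a number, so the full size of this step stays unknown: the limit of < 0.0667 h in this assay, at which 1 of the 3 values shown sits.

This change swaps the ring and adds a methyl at once, and the compounds shown cannot separate the two. An imidazole without the methyl would tell them apart.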